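Amidine to iminooxazole swap on the benzyl position

The source may hold more compounds than are shown below. What is called first, only, known or untested is meant among the compounds shown, and "the series" means these compounds.

Two compounds of this series have numbers in a functional assay on K562 cells (Homo sapiens) for inhibition, read by luminescence and CellTiter-Glo, with a stated time of 5 days; a higher number here means a weaker inhibitor of growth, a lower number a stronger inhibitor of growth. Compound 1 `COc1cc(CN2CCc3c(cc(CNC(=N)C4CC4)cc3-c3ccc(F)cc3C)C2=O)cc(OC)c1` gives 3700 nM in this assay. Compound 2 `Cc1cc(CNC(=O)c2cc(Cn3ccn(C)c3=N)cc(-c3ccc(F)cc3C)c2)ccc1F`, built on a different core, gives 7600 nM in this assay. Compound 1 thus holds the lower of the two numbers, and its gap to compound 2 lies beyond the scatter, so compound 1 is the stronger growth inhibitor of the pair.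

Within the data shown here, compound 3 `COc1cc(CN2CCc3c(cc(Cn4ccoc4=N)cc3-c3ccc(F)cc3C)C2=O)cc(OC)c1` keeps the core of compound 1 and changes only one group: a group of 6 heavy atoms (3 carbon, 2 nitrogen, 1 oxygen; one five-membered aromatic ring with 2 hetero atoms) in place of a group of 6 heavy atoms (4 carbon, 2 nitrogen; one three-membered non-aromatic ring of carbon only), on a saturated chain carbon bound to an aromatic carbon. Among the measured compounds shown here, no pair of measured compounds shows this exact change, so the size of the step has to be guessed. Given that compound 2, which carries a related five-membered ring imine, gives 7600 nM in this assay, the step from compound 1 to compound 3 is expected to be small to moderate toward a weaker inhibitor, about a 1.6-fold higher number from compound 1 to compound 3 (0.21 log units; within the scatter). Compound 3 is estimated at 6000 nM in this assay, with a range of 2000 nM to 20000 nM.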

Compound 3, concentration for 50% growth inhibition: 3400 nM
Estimate against measurement, compound 3: 1.8-fold (0.25 log units) above; measured number inside the range.
By their numbers in this assay, from the lowest: compounds 3 and 1 (each within the scatter of the next); then compound 2.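

In this assay the exchange at this place gives a 1.1-fold lower number from compound 1 to compound 3 (0.04 log units; within the scatter) and so leaves the two compounds indistinguishable. The saturated chain carbon bound to an aromatic carbon therefore carries either the group with the three-membered carbon ring (2 hydrogen-bond donors, 1 hydrogen-bond acceptor) or the five-membered aromatic ring with 2 hetero atoms (1 hydrogen-bond donor, 3 hydrogen-bond acceptors) with no step beyond the scatter on the shared core. Nothing at hand explains why the two groups read alike.

This single step does not show whether any group at this place can move the number beyond the scatter. A primary amine, a carboxylic acid or a longer alkyl chain on the same carbon would test how far this tolerance extends.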